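The compounds below may be only part of what the source reports. "The series", "measured", "known", "first", "only" and "open" are said of these compounds alone.

Measured in a functional assay on A498 cells (Homo sapiens) for cytotoxicity; on this read-out lower numbers stand for stronger inhibition of growth and higher numbers for weaker inhibition of growth:
- compound 1 `COc1ccc(C2=C(c3ccc(SC)cc3)CC3CCCN3C2=O)cc1C`: 400 nM
- compound 2 `CSc1ccc(C2=C(c3ccc(C)c(C)c3)C(=O)N3CCCC3C2)cc1`: 300 nM
- compound 3 `CSc1ccc(C2=C(c3ccc(O)cc3)C(=O)N3CCCC3C2)cc1`: > 100000 nM

Compound 3 is known only through a limit, (the limit of > 100000 nM in this assay, at which 1 of the 3 values shown sits), and has no number of its own.

The next step leads to compound 4 `CSc1ccc(C2=C(c3ccc(SC)cc3)C(=O)N3CCCC3C2)cc1`, still unmeasured. The change is methylsulfanyl in place of hydroxy on an aromatic carbon, para to a large group.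

The closest evidence comes from two large measured steps, an at least 250-fold higher number from compound 1 to compound 3 (2.39 log units; beyond the scatter) and an at least 330-fold higher number from compound 2 to compound 3 (2.52 log units; beyond the scatter), each of which ends in the 4-hydroxyphenyl group. The step of a 1.3-fold lower number from compound 1 to compound 2 (0.12 log units; within the scatter) shows that these two compounds without the hydroxy group sit together. Compound 4 also lacks the hydroxy group, so a large step to a lower number is expected in this assay, roughly the reverse of those two steps. This reasoning rests on compound 1 at 400 nM and compound 2 at 300 nM.

The expected change is an at least 330-fold lower number from compound 3 to compound 4 (2.52 log units; beyond the scatter).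

The estimated value for compound 4 is 300 nM, with an expected range of 80 nM to 1500 nM.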

Compound 4, concentration for 50% growth inhibition: 15000 nM
Beside the measured number, compound 4's estimate is 50-fold (1.70 log units) below it; the measured number lies above the stated range.
By their numbers in this assay, from the lowest: compounds 2 and 1 (each within the scatter of the next); then compound 4. At a limit, above all of these: compound 3.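

In this assay, methylsulfanyl in place of hydroxy on this aromatic carbon restores only part of the growth inhibition, an at least 6.6-fold lower number from compound 3 to compound 4 (0.82 log units; beyond the scatter), and the true size of this step stays open, as the value of compound 3 is a limit: the limit of > 100000 nM in this assay, at which 1 of the 4 values shown sits.

Removing the hydroxy group is not enough to match the other two compounds: 4-(methylsulfanyl)phenyl in place of 3,4-dimethylphenyl gives a 50-fold higher number from compound 2 to compound 4 (1.70 log units; beyond the scatter), and in place of 4-methoxy-3-methylphenyl it gives a 38-fold higher number from compound 1 to compound 4 (1.57 log units; beyond the scatter). The identity of the group at this site therefore matters beyond the presence or absence of hydroxy.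

The compounds shown leave open how an amine or a carboxylic acid would read in place of the methylsulfanyl group. They also leave open whether a longer chain, such as ethylsulfanyl, would move the number in either direction.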